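Step from compound 2 to compound 3: a second methyl

The compounds below may be only part of what the source reports. "The series", "measured", "known", "first", "only" and "open" are said of these compounds alone.

Measured so far in a functional assay on CHO cells for positive allosteric modulation of metabotropic glutamate receptor 2 (Homo sapiens), read by scintillation counting and GTPgammaS binding, with a stated time of 30 min; on this read-out higher numbers stand for an effect only at larger amounts of compound and lower numbers for an effect already at smaller amounts:
compound 1 `CCCCn1ccc(-c2ccc(Oc3ccnc(C)c3)c(Cl)c2)c(C#N)c1=O`: 166 nM
compound 2 `CCCCn1ccc(-c2ccc(Oc3cccnc3C)c(Cl)c2)c(C#N)c1=O`: 100 nM
compound 3 `CCCCn1ccc(-c2ccc(Oc3ccc(C)nc3C)c(Cl)c2)c(C#N)c1=O`: not yet measured

Among the compounds with values here, compound 2 carries the lowest of the two numbers in this assay; its only neighbour is compound 1, and the step of a 1.7-fold lower number from compound 1 to compound 2 (0.22 log units; within the scatter) stays within the scatter, so the two cannot be ranked. Compound 3 arises from compound 2 by methyl in place of hydrogen on an aromatic carbon. Within the data shown here, the one measured step, a 1.7-fold lower number from compound 1 to compound 2 (0.22 log units; within the scatter), moved the methyl-bearing ring from one attachment to the other rather than adding a methyl, and it was small; no measured pair adds a methyl to this ring. Among the measured compounds shown here, because the sole step a 1.7-fold lower number from compound 1 to compound 2 (0.22 log units; within the scatter) lies within the scatter, no movement beyond the scatter is expected for compound 3 in this assay, so compound 3 is estimated at 100 nM with a range of 35 nM to 300 nM. This estimate corresponds to an expected step of no change at the digits printed from compound 2 to compound 3 (within the scatter).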

Compound 3, half-maximal effective concentration: 30 nM
Estimate against measurement, compound 3: 3.3-fold (0.52 log units) above; the whole stated range lies above it.
By their numbers in this assay, from the lowest: compound 3; then compounds 2 and 1 (each within the scatter of the next).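

In this assay, a methyl on the aromatic carbon next to the ring nitrogen, para to the large group, gives a 3.3-fold lower number from compound 2 to compound 3 (0.52 log units; beyond the scatter), so this position can affect the read-out, which the earlier pair could not show. The change from 2-methylpyridin-4-yl to 2,6-dimethylpyridin-3-yl gives a 5.5-fold lower number from compound 1 to compound 3 (0.74 log units; beyond the scatter), also beyond the scatter, whereas a 1.7-fold lower number from compound 1 to compound 2 (0.22 log units; within the scatter) stays within it. No measurement at hand bears on the reason for the effect of this methyl.

Open, on these data alone, is whether an ethyl, a methoxy or a chlorine in this position would give a similar step or whether it is specific to methyl. Also open, as far as these compounds go, is whether the step depends on the methyl already present in 2-methylpyridin-3-yl, which a 6-methylpyridin-3-yl ring would test.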